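Shifting a methoxy group on the benzyl ring

The source may report more compounds than this note shows. Statements on the series, on what has been measured and on what is new or still open speak of the compounds shown alone.

Measured compounds:
compound 1, `COc1cccc(OC)c1OCCNCCOc1ccccc1OCc1ccc(C)cc1`, gives 9.12 in a functional assay on thoracic aorta for antagonist activity at Alpha-1D adrenergic receptor (Rattus norvegicus); a higher number here means a more potent compound, by a factor of ten per unit of this negative logarithm, a lower number a less potent compound.
compound 2, `COc1cccc(COc2ccccc2OCCNCCOc2c(OC)cccc2OC)c1`, gives 9.12 in this assay.

Compound 2 stands level with compound 1 on these numbers. Among the measured compounds shown here, the only measured step, no change at the digits printed from compound 1 to compound 2 (within the scatter), exchanges 4-methylphenyl for 3-methoxyphenyl on a saturated chain carbon bound to an oxygen on an aromatic ring, and this exchange left the read-out unchanged within the scatter.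

Compound 3, `COc1ccc(COc2ccccc2OCCNCCOc2c(OC)cccc2OC)cc1`, is the next step from compound 2: 4-methoxyphenyl in place of 3-methoxyphenyl on a saturated chain carbon bound to an oxygen on an aromatic ring. The change sits at the same place as the measured step, and that step showed no effect. For the measured compounds named here, no measured pair compares a 3-methoxyphenyl with a 4-methoxyphenyl, so the direct information is missing; what the data give is that one substitution pattern at this place did not move this assay.

The expectation is therefore no step beyond the scatter, with a number 0.12 log units lower from compound 2 to compound 3 (within the scatter) as the estimated change. Compound 3 is expected to give about 9, within a range from 8.5 to 9.5.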

Compound 3, negative logarithm of the antagonist equilibrium constant: 9.21
Beside the measured number, compound 3's estimate is 0.21 log units below it; measured number inside the range.
By their numbers in this assay, from the lowest: compounds 1, 2 and 3 (each within the scatter of the next).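

In this assay, among the compounds shown here, exchanging 3-methoxyphenyl for 4-methoxyphenyl gives a number 0.09 log units higher from compound 2 to compound 3 (within the scatter) and so provides the first direct comparison of these two groups on a saturated chain carbon bound to an oxygen on an aromatic ring; the position of the methoxy group on the benzyl ring makes no difference beyond the scatter. The result also allows a second comparison, in which methoxy in place of methyl on an aromatic carbon gives a number 0.09 log units higher from compound 1 to compound 3 (within the scatter) and likewise stays within the scatter. The 3-methoxybenzyl, 4-methoxybenzyl and 4-methylbenzyl versions therefore cannot be told apart in this assay, and nothing available explains why these exchanges leave the read-out in place.

From the compounds shown here alone, all three compounds keep a methoxy or methyl group on the benzyl ring, so it remains open how a carboxylic acid, an amine or a longer chain such as butoxy would read at this place. Whether 3-methoxyphenyl and 4-methoxyphenyl would also stay level at any other receptor cannot be read from these numbers.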